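Adding a nitrophenyl group to a spiro thiophene scaffold

This account rests on a few compounds, and the source may have more. Where it says the series, first, only, none or still open, it means among the compounds named here.

Measured compounds:
compound 1 `COc1ccc(-c2scc3c2CCOC32CCN(Cc3ccccc3)CC2)cc1` gives 1.5 nM
compound 2 `N#Cc1ccc(-c2scc3c2CCOC32CCN(Cc3ccccc3)CC2)cc1` gives 3.4 nM
compound 3 `COC1Cc2cscc2C2(CCN(Cc3ccccc3)CC2)O1` gives 0.22 nM

In an assay on membranes from brain for displacement of a labelled ligand from Sigma non-opioid intracellular receptor 1 (Cavia porcellus), read by scintillation counting, with a stated time of 120 min (on this read-out higher numbers stand for weaker inhibition and lower numbers for stronger inhibition), compound 3 shows the lowest number of the three, well separated from compound 1 and compound 2, which differ from it both by carrying an aryl group on the thiophene ring and by lacking the methoxy group on the neighbouring saturated ring. Compound 4 `COC1Cc2c(csc2-c2ccc([N+](=O)[O-])cc2)C2(CCN(Cc3ccccc3)CC2)O1` is compound 3 with 4-nitrophenyl in place of hydrogen on an aromatic carbon. Among the compounds with values here, no measured pair isolates exactly this change. Within the data shown here, the one single-point step, a 2.3-fold higher number from compound 1 to compound 2 (0.36 log units; beyond the scatter), shows that exchanging the substituent on such an aryl group shifts the number only modestly. Since both aryl-bearing compounds sit well above compound 3, the nitrophenyl addition is expected to move compound 4 toward those values, in the direction of a higher number in this assay. Compound 4 is therefore estimated at 1.5 nM, within 0.4 nM to 6 nM, an expected step of a 6.8-fold higher number from compound 3 to compound 4 (0.83 log units; beyond the scatter).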

Compound 4, inhibition constant: 1 nM
Beside the measured number, compound 4's estimate is 1.5-fold (0.18 log units) above it; the measured number falls inside the stated range.
By their numbers in this assay, from the lowest: compound 3; then compounds 4 and 1 (each within the scatter of the next); then compound 2.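

In this assay, placing 4-nitrophenyl on this aromatic carbon next to the ring sulfur gives a 4.5-fold higher number from compound 3 to compound 4 (0.66 log units; beyond the scatter) and so has a real but modest effect on the number. Within the data shown here, the earlier compounds could only compare one substituted aryl group with another, whereas compound 3 and compound 4 differ in this one place, so this is the first direct reading of what adding an aryl group here does. Nothing measured among these compounds explains the size of this step.

Among the compounds shown, the methoxy-bearing core carries only this one aryl group, so it remains open how a plain phenyl, a methyl or an amine at this carbon would compare. Also open, going by these compounds, is whether a carboxylic acid in place of the nitro group would change the number.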